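Removing the Piperazine Arm: What Compound 4 Might Show

The source may report more compounds than this note shows. Statements on the series, on what has been measured and on what is new or still open speak of the compounds shown alone.

Compound 1 `CCN(CC)c1ccc(-n2cc(-c3ccc(C)c(Nc4nccc(-c5cccnc5)n4)c3)nn2)cc1` in a functional assay on HL-60 cells (Homo sapiens) for inhibition, read by MTT assay, with a stated time of 72 h (a higher number here means a weaker inhibitor, a lower number a stronger inhibitor), gives 13600 nM.
Compound 2 `Cc1ccc(-c2nnc(-c3ccc(CN4CCN(C)CC4)cc3)o2)cc1Nc1nccc(-c2cccnc2)n1` in this assay gives 570 nM.
Compound 3 `Cc1ccc(-c2nnc(-c3ccc(CN4CCN(C)CC4)c(C(F)(F)F)c3)o2)cc1Nc1nccc(-c2cccnc2)n1` in this assay gives 50 nM.

Compound 3 has the lowest number of the three and is therefore the strongest inhibitor among them; its gaps to compound 2 and to compound 1 are both beyond the scatter. Among the measured compounds shown here, the only single-point step that has been measured, an 11-fold lower number from compound 2 to compound 3 (1.06 log units; beyond the scatter), concerns a trifluoromethyl group and not the part that changes here.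

Compound 4 `Cc1ccc(-c2nnc(-c3ccc(C)c(C(F)(F)F)c3)o2)cc1Nc1nccc(-c2cccnc2)n1` differs from compound 3 by hydrogen in place of 4-methylpiperazin-1-yl on a saturated chain carbon bound to an aromatic carbon. For the measured compounds named here, no measured pair differs in this place, so nothing in the data shows directly how large such a change is in this assay. Compound 1 and compound 2 differ from each other in several places at once and give no single-point reading either.

With no direct guide, the expectation is that compound 4 shows a step of a 5.0-fold higher number from compound 3 to compound 4 (0.70 log units; beyond the scatter) in this assay toward a higher number, that is a somewhat weaker inhibitor, with wide uncertainty. Compound 4 is estimated at 250 nM, with a range from 60 nM to 1200 nM.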

Compound 4, half-maximal inhibitory concentration: > 30000 nM
Compound 4 was reported as a limit; the forecaster's own chance of this, stated with the estimate: 2%; middle value at least 120-fold (2.07 log units) from the limit.
By their numbers in this assay, from the lowest: compound 3; then compound 2; then compound 1. At a limit, above all of these: compound 4.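

In this assay compound 4 is reported only as a limit of the assay and not as a number: the limit of > 30000 nM in this assay, at which 1 of the 4 values shown sits. Among the compounds shown here, replacing 4-methylpiperazin-1-yl with hydrogen on a saturated chain carbon bound to an aromatic carbon gives an at least 600-fold higher number from compound 3 to compound 4 (2.77 log units; beyond the scatter), the first single-point reading at this place. This step is much larger than the one seen with trifluoromethyl, an 11-fold lower number from compound 2 to compound 3 (1.06 log units; beyond the scatter), and the trifluoromethyl group that compound 3 and compound 4 share does not by itself keep compound 4 close to compound 3.

The compounds shown leave open which part of the 4-methylpiperazin-1-yl group matters, since the only replacement here is hydrogen. A simple dimethylamine, a morpholine ring or a carboxylic acid at the same place could separate the need for an amine from the need for a ring.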